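Swapping the aminoethyl carbamoyloxy tail for a pyridine

The compounds below may be only part of what the source reports. "The series", "measured", "known", "first", "only" and "open" are said of these compounds alone.

Three analogues sharing one core have been measured in an assay on membranes from brain for inhibition of sphingomyelin phosphodiesterase 2 (Rattus norvegicus), using microsomes; a higher number here means a weaker inhibitor, a lower number a stronger inhibitor. Compound 1, `CCCCCCCCCCCCC/C=C/[C@@H](O)[C@H](COC(=O)NCCN(C)C)NC(=O)C(C)(C)C`, gives 4100 nM. Compound 2, `CCCCCCCCCCCCC/C=C/[C@@H](O)[C@H](COC(=O)NCCCN(C)C)NC(=O)C(C)(C)C`, gives 4900 nM, and compound 3, `CCCCCCCCCCCCC/C=C/[C@@H](O)[C@H](COC(=O)NCCN(C(C)C)C(C)C)NC(=O)C(C)(C)C`, gives 18000 nM. Compound 1 therefore carries the lowest number of the three: the step of a 1.2-fold higher number from compound 1 to compound 2 (0.08 log units; within the scatter) lies within the scatter, while the step of a 4.4-fold higher number from compound 1 to compound 3 (0.64 log units; beyond the scatter) is a clear, if modest, loss of inhibition. The new compound 4, `CCCCCCCCCCCCC/C=C/[C@@H](O)[C@H](COC(=O)Nc1ccccn1)NC(=O)C(C)(C)C`, differs from compound 1 in a single place: pyridin-2-yl in place of 2-(dimethylamino)ethyl on an amide-type nitrogen. The carbamoyloxy linker stays, but the 2-(dimethylamino)ethyl chain gives way to a six-membered aromatic ring with one hetero atom. Among the measured compounds shown here, the only guidance comes from changes at the same amino end. Putting (dimethylamino)methyl in place of dimethylamino, a 1.2-fold higher number from compound 1 to compound 2 (0.08 log units; within the scatter), changed little, whereas putting diisopropylamino in place of dimethylamino, a 4.4-fold higher number from compound 1 to compound 3 (0.64 log units; beyond the scatter), weakened inhibition. Removing the whole chain is a larger departure than either, so a modest weakening is expected here, with wide uncertainty around it. The expected step is a 2.2-fold higher number from compound 1 to compound 4 (0.34 log units; beyond the scatter). Compound 4 is accordingly estimated at 9000 nM, with a likely range from 3000 nM to 30000 nM.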

Compound 4, half-maximal inhibitory concentration: 7900 nM
Compound 4: middle estimate off by 1.1-fold (0.06 log units), on the high side, within the range that was stated.
By their numbers in this assay, from the lowest: compounds 1, 2 and 4 (each within the scatter of the next); then compound 3.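

In this assay, both the step of a 1.9-fold higher number from compound 1 to compound 4 (0.28 log units; within the scatter) and the step of a 1.6-fold higher number from compound 2 to compound 4 (0.21 log units; within the scatter) stay within the scatter, so on this amide-type nitrogen the open chain ending in dimethylamino can be replaced by the aromatic pyridin-2-yl ring with no measurable difference. Among the compounds shown here, the remaining comparison, a 2.3-fold lower number from compound 3 to compound 4 (0.36 log units; beyond the scatter), lies beyond the scatter, which leaves the 2-(diisopropylamino)ethyl chain of compound 3 as the only group among the four that stands apart, and shows that inhibition at this level does not depend on keeping a chain with an amine at its end. No supporting measurement is available to explain why these groups compare as they do.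

Going by these compounds, whether the nitrogen of the ring matters remains open, and phenyl, pyridin-3-yl or pyridin-4-yl on the same amide-type nitrogen would address that question. It is also unknown whether a chain ending in a carboxylic acid instead of an amine would keep inhibition near that of compound 1, at 4100 nM.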